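The compounds below may be only part of what the source reports. "The series", "measured", "known", "first", "only" and "open" are said of these compounds alone.

Compound 1 `C=CC(=O)Nc1cc(Nc2nccc(NC(=O)c3ccc(C(F)(F)F)cc3)n2)c(OC)cc1N1CCN(C)CC1`: > 10000 nM
Compound 2 `C=CC(=O)Nc1cc(Nc2nccc(NC(=O)c3ccccc3)n2)c(OC)cc1N(C)CCN(C)C`: 3580 nM

Both compounds were tested in a functional assay on ASPC1 cells (Homo sapiens) for antiproliferative activity, read by MTT assay, with a stated time of 72 h; a higher number here means a weaker inhibitor, a lower number a stronger inhibitor. The entry for compound 1 is a limit, not a number. Among the compounds with values here, compound 2, at 3580 nM, therefore holds the only numerical value so far. The next compound is compound 3 `C=CC(=O)Nc1cc(Nc2nccc(NC(=O)c3ccccc3)n2)c(OC)cc1N1CCN(C)CC1`, with 4-methylpiperazin-1-yl in place of (2-(dimethylamino)ethyl)(methyl)amino on an aromatic carbon. Within the data shown here, no measured step shows the size of this change. Compound 1 carries the same 4-methylpiperazin-1-yl group, and its > 10000 nM is a limit. A modest weakening is therefore expected, though it may not clear the scatter. The expected change is a 1.4-fold higher number from compound 2 to compound 3 (0.15 log units; within the scatter). Compound 3 is estimated at 5000 nM, within a range of 2000 nM to 12000 nM.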

Compound 3, half-maximal inhibitory concentration: > 10000 nM
Compound 3: no number, only a limit (the forecaster's own chance of this, stated with the estimate: 30%); middle value at least 2.0-fold (0.30 log units) away from the limit.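

In this assay, within the data shown here, 4-methylpiperazin-1-yl in place of (2-(dimethylamino)ethyl)(methyl)amino, on the aromatic carbon ortho to the (vinylcarbonyl)amino group, gives an at least 2.7-fold higher number from compound 2 to compound 3 (0.44 log units; beyond the scatter), the first readable step. The leaving and entering groups match in heavy atoms, so this step separates a ring from an open chain at this position. The step from compound 1 to compound 3 cannot be read, and the other step has only a lower bound because compound 3 gives a limit: the limit of > 10000 nM in this assay, at which 2 of the 3 values shown sit.

Open, as far as these compounds go, is whether a morpholine or a longer chain ending in dimethylamino at this position would give a number. Also open, from the compounds shown here alone, is what trifluoromethyl does alongside the (2-(dimethylamino)ethyl)(methyl)amino group.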